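Bicyclic amine in place of the pyrrolidine side chain

The source may report more compounds than this note shows. Statements on the series, on what has been measured and on what is new or still open speak of the compounds shown alone.

In an assay on isolated protein for inhibition of DNA topoisomerase 1 (Homo sapiens), with a stated time of 15 min (a higher number here means a weaker inhibitor, a lower number a stronger inhibitor), the three measured compounds gave:
Compound 1 `COc1c(N2CC[C@@H](CN)C2)c(F)cc2c(=O)c(C(=O)O)cn(Cc3cc(-c4ccccc4)no3)c12` — 178000 nM
Compound 2 `CNC[C@@H]1CCN(c2cc3c(cc2F)c(=O)c(C(=O)O)cn3Cc2ccc(-n3cccn3)cc2)C1` — > 200000 nM, which is a limit of the assay and not a number
Compound 3 `CNC[C@@H]1CCN(c2cc3c(cc2F)c(=O)c(C(=O)O)cn3Cc2ccc(-c3ccccc3)cc2)C1` — 168000 nM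

Compound 2 stands at the weak end of what was measured. Its value is only a limit, and the limit of > 200000 nM in this assay, at which 1 of the 3 values shown sits, is where it sits. The one measured step among these compounds, an at least 1.1-fold lower number from compound 2 to compound 3 (0.07 log units; that floor lies within the scatter), lies within the scatter, and it concerns the aryl substituent, not the amine side chain.

Compound 4 `O=C(O)c1cn(Cc2ccc(-n3cccn3)cc2)c2cc(N3C[C@H]4CCNC[C@H]4C3)c(F)cc2c1=O` differs from compound 2 in that side chain: a group of 9 heavy atoms (7 carbon, 2 nitrogen; one five-membered non-aromatic ring with 1 hetero atom, one six-membered non-aromatic ring with 1 hetero atom) in place of a group of 8 heavy atoms (6 carbon, 2 nitrogen; one five-membered non-aromatic ring with 1 hetero atom), on an aromatic carbon. No measured pair among these compounds touches that change, so nothing here says how this assay responds to it. With compound 2 itself only a limit, the step from compound 2 to compound 4 is expected to be small, a number no higher from compound 2 to compound 4 (the limit leaves the size open), and of no settled direction beyond the scatter.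

Compound 4 is therefore expected to give about 200000 nM in this assay, in a range from 90000 nM to 450000 nM, with a fair chance that only a limit is reported again.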

Compound 4, half-maximal inhibitory concentration: 31300 nM
Compound 4: middle estimate off by 6.4-fold (0.81 log units), on the high side; measured number outside the range, below it.
By their numbers in this assay, from the lowest: compound 4; then compounds 3 and 1 (each within the scatter of the next). At a limit, above all of these: compound 2.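

In this assay, among the compounds shown here, the position on the aromatic carbon ortho to a fluoro group proves responsive to a change of amine, something the earlier compounds could not show, as their one measured step concerned the aryl substituent. Putting the bicyclic amine in place of 3-((methylamino)methyl)pyrrolidin-1-yl gives an at least 6.3-fold lower number from compound 2 to compound 4 (0.80 log units; beyond the scatter), and the 1H-pyrazol-1-yl group stays the same in this pair, so the step belongs to the side chain alone. Its full size cannot be read, as the entry for compound 2 is a limit and not a number: the limit of > 200000 nM in this assay, at which 1 of the 4 values shown sits.

The compounds shown leave open which feature of the new amine carries the step, the second ring or the two defined stereocentres, and whether the step would hold with phenyl in place of 1H-pyrazol-1-yl, as in compound 3. Also open, going by these compounds, is how the mirror-image form of the bicyclic amine, a simple piperazine, or the same bicyclic amine with a methyl group on its ring nitrogen would read in this assay.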